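The source may report more compounds than this note shows. Statements on the series, on what has been measured and on what is new or still open speak of the compounds shown alone.

The measured compounds are:

compound 1, `CN(CC1CCC/C(=C\c2ccccc2)C1=O)c1ccccc1`, with 49.7% in a functional assay on the whole organism (Ear, strain Kunming) for inhibition, with Mus musculus as the target, with stated times of 1 h and 30 min, at a dose of 200 mg/kg by the oral route; on this read-out higher numbers stand for more inhibition at the one dose given (going by the name of the read-out) and lower numbers for less inhibition;
compound 2, `Cc1cccc(N(C)CC2CCC/C(=C\c3ccccc3)C2=O)c1`, with 44.9% in this assay;
compound 3, `COc1ccc(C2(O)/C(=C/c3ccccc3)CCCC2CN(C)c2ccccc2)cc1`, with 26.5% in this assay.

Compound 1 and compound 2 share a core and differ only in one spot: methyl in place of hydrogen on an aromatic carbon. The step that this change made is a number 4.8 percentage points lower from compound 1 to compound 2 (within the scatter), so the two compounds cannot be told apart on this read-out.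

Compound 3 is built on another core, and the difference between the two cores is not broken down here. What the values show is that compound 3 stands beyond the scatter below both compound 1 and compound 2 in this assay.

Compound 4, `COc1ccc(C2(O)/C(=C/c3ccc(C)cc3)CCCC2CN(C)c2ccccc2)cc1`, has not yet been measured. It comes from compound 3 by the same kind of change as compound 2 comes from compound 1: methyl in place of hydrogen on an aromatic carbon. The surroundings of the place are not the same word for word: in compound 2 the methyl sits on an aromatic carbon of a six-membered aromatic ring of carbon only, meta to a large group, whereas in compound 4 it sits on an aromatic carbon of a six-membered aromatic ring of carbon only, para to a large group. The change is therefore the same kind of change, not the same.

Because the earlier step was a number 4.8 percentage points lower from compound 1 to compound 2 (within the scatter), the expected step here is also small, a number 3.5 percentage points lower from compound 3 to compound 4 (within the scatter), and it is expected to stay within the scatter. On that basis compound 4 is estimated to give 23% in this assay, with the likely range from 10% to 38%.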

Compound 4, a percentage reported as inhibition, in the whole organism at one dose (the size of the read-out at that dose, not a potency): 16.3%
For compound 4 the middle estimate is 6.7 percentage points above the measured one; measured number inside the range.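

The same change, methyl in place of hydrogen on an aromatic carbon, can now be read on two cores in this assay, and on the core of compound 3 it gives a number 10.2 percentage points lower from compound 3 to compound 4 (beyond the scatter) on that read-out. Set beside the earlier step, the new one does not separate from it: the same change on two cores in this assay, a number 4.8 percentage points lower (within the scatter) from compound 1 to compound 2 and a number 10.2 percentage points lower (beyond the scatter) from compound 3 to compound 4, 5.4 percentage points apart, within the scatter of two such steps. The two steps therefore fit a single modest effect of the change on either core, but they do not prove that the effect is the same on both or that it is real on the core of compound 1, and two pairs, with the methyl at a different place in each, are too few to show how reliably the step carries from one core to another.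

The compounds shown change the aromatic ring only by adding a methyl, so it remains open how a chlorine atom, an amine or a carboxylic acid at the same place would affect the number. On these data alone, it also remains open whether the methyl step would hold on further cores, and whether the two cores would respond alike if the methyl stood at the same place on both.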